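The source may hold more compounds than are shown below. What is called first, only, known or untested is meant among the compounds shown, and "the series" means these compounds.

This account follows the change from compound 1, `Cc1cc(C)c(-c2nc(CN3CCC(C(=O)NCCCN4C[C@H](C)C[C@H](C)C4)CC3)c(C)o2)c(C)c1`, to compound 3, `CCc1ccccc1-c1nc(CN2CCC(C(=O)NCCCN3C[C@H](C)C[C@H](C)C3)CC2)c(C)o1`, in an ADME assay on microsomes from liver (Rattus norvegicus) for metabolic stability, read by LC-MS, using NADPH, at 37 degrees C; a lower number here means that the compound disappears faster, a higher number that the compound lasts longer. In this assay compound 1 gives > 0.5 h, which is a limit of the assay and not a number. Compound 1 thus stands at the limit of > 0.5 h in this assay, at which 1 of the 2 values shown sits, so its place on the scale is known from one side only. Compound 2, `Cc1cccc(Cl)c1-c1nc(CN2CCC(C(=O)NCCCN3CCC(C(C)C)CC3)CC2)c(C)o1`, carries a different aryl group and a different amine, and in this assay compound 2 gives 0.0333 h. Going by the values given here, no step between measured compounds that differ in a single place is available, so the two values show only that the series spans a wide range. The change to compound 3 is 2-ethylphenyl in place of 2,4,6-trimethylphenyl on an aromatic carbon. For this change a step toward shorter half-life is expected, of a size somewhat beyond the scatter. Compound 3 is therefore estimated at 0.2 h, with a range from 0.05 h to 0.6 h. That estimate corresponds to an expected step of an at least 2.5-fold lower number from compound 1 to compound 3 (0.39 log units; beyond the scatter).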

Compound 3, half-life: 0.283 h
Compound 3: middle estimate off by 1.4-fold (0.15 log units), on the low side; measured number inside the range.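

In this assay, going by these compounds alone, the change to 2-ethylphenyl in place of 2,4,6-trimethylphenyl gives the first comparison at this aromatic carbon with the rest of the molecule held constant: an at least 1.7-fold lower number from compound 1 to compound 3 (0.24 log units; that floor lies within the scatter). Compound 3 gives 0.283 h, a measured number, whereas compound 1 gives > 0.5 h, which is a limit of the assay and not a number. The true size of the step therefore remains unknown, and only its floor can be stated, because one end of the step is that limit: the limit of > 0.5 h in this assay, at which 1 of the 3 values shown sits.

The compounds shown do not separate the contribution of the ethyl group from that of the methyl groups on the ring that leaves. As far as these compounds go, how a plain phenyl or a 2-methoxyphenyl at this place would behave also remains open, as does the effect of changing the amine alone.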